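Chain length of the hydroxamate arm on two cores

The compounds below may be only part of what the source reports. "The series", "measured", "known", "first", "only" and "open" are said of these compounds alone.

Measured so far:
compound 1, `Nc1ncnc2c1c(-c1cnc3[nH]ccc3c1)nn2CCCCCC(=O)NO`: > 150000 nM
compound 2, `Nc1ncnc2c1c(-c1cnc3[nH]ccc3c1)nn2CCCCCCC(=O)NO`: 50000 nM
compound 3, `Nc1nc2cc(-c3nn(CCCCC(=O)NO)c4ncnc(N)c34)ccc2o1`: > 100000 nM

All readings come from a functional assay on A549 cells (Homo sapiens) for inhibition, read by MTT assay, with a stated time of 72 h; a lower number here means a stronger inhibitor, a higher number a weaker inhibitor. For compound 1 the reading is a limit of the assay, not a number. For compound 3 the reading is also a limit. Only compound 2 gives a number. The step of an at least 3.0-fold lower number from compound 1 to compound 2 (0.47 log units; beyond the scatter) goes with the change ((hydroxycarbamoyl)methyl in place of hydroxycarbamoyl on a saturated chain carbon, five bonds along the chain from an aromatic nitrogen). How the core of compound 3 differs from the core of compound 1 is not broken down here.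

Compound 4, `Nc1nc2cc(-c3nn(CCCCCC(=O)NO)c4ncnc(N)c34)ccc2o1`, is not yet measured. It differs from compound 3 by (hydroxycarbamoyl)methyl in place of hydroxycarbamoyl on a saturated chain carbon, four bonds along the chain from an aromatic nitrogen. This is the same kind of change as between compound 1 and compound 2, though the place differs: four bonds along the chain from an aromatic nitrogen rather than five.

Compound 4 is expected to show a step of an at least 2.0-fold lower number from compound 3 to compound 4 (0.30 log units; that floor lies within the scatter) in this assay, an expectation that rests on the step of an at least 3.0-fold lower number from compound 1 to compound 2 (0.47 log units; beyond the scatter). Compound 4 is therefore estimated at 50000 nM, within 10000 nM to 200000 nM, with a fair chance that only a limit is reported.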

Compound 4, half-maximal inhibitory concentration: > 100000 nM
Compound 4: only a limit was reported; the forecaster's own chance of this, stated with the estimate: 40%; middle value at least 2.0-fold (0.30 log units) from the limit.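

In this assay compound 4 gives > 100000 nM as a limit of the assay, not a number. Among the compounds shown here, no step from compound 3 to compound 4 can be read, because both readings rest at the same limit: the limit of > 100000 nM in this assay, at which 2 of the 4 values shown sit. Still open, from the compounds shown here alone, is whether the step seen from compound 1 to compound 2 carries over to the core of compound 3.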